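This account rests on a few compounds, and the source may have more. Where it says the series, first, only, none or still open, it means among the compounds named here.

Measured so far:
compound 1, `Cc1ncnc2c1c(I)cn2[C@@H]1O[C@H](CO)[C@@H](O)[C@H]1O` — 12200 nM
compound 2, `CNc1ncnc2c1c(I)cn2[C@@H]1O[C@H](CO)[C@@H](O)[C@H]1O` — > 100000 nM

For the measured compounds named here, compound 1 carries the only numeric value: in a functional assay on A549 cells (Homo sapiens), read by MTT assay, with a stated time of 72 h (on this read-out lower numbers stand for stronger inhibition and higher numbers for weaker inhibition), compound 1 gives 12200 nM. For compound 2 the read-out is a limit of the assay, not a number: in this assay compound 2 gives > 100000 nM. The step of an at least 8.1-fold higher number from compound 1 to compound 2 (0.91 log units; beyond the scatter) is therefore open-ended because of the limit of > 100000 nM in this assay, at which 1 of the 2 values shown sits.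

Compound 3, `Cc1ncnc2c1c(-c1ccsc1)cn2[C@@H]1O[C@H](CO)[C@@H](O)[C@H]1O`, departs from compound 1 at a different place: thiophen-3-yl in place of iodo on an aromatic carbon. Going by the values given here, the single measured step concerns the group on the other aromatic carbon, so it offers no guide to the exchange of iodo for thiophen-3-yl; the direction and size of the step in this assay for compound 3 rest on no measured comparison here. As a working figure, a step of an 8.1-fold lower number from compound 1 to compound 3 (0.91 log units; beyond the scatter) is expected. Compound 3 is thus estimated at 1500 nM, with a wide range from 100 nM to 15000 nM.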

Compound 3, half-maximal inhibitory concentration: > 20000 nM
Compound 3: a limit, no number (the forecaster's own chance of this, stated with the estimate: 10%); middle value at least 13-fold (1.12 log units) away from the limit.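

In this assay compound 3 gives > 20000 nM, a limit of the assay and not a number. For the compounds shown here, this is the first measured step at the carbon bearing iodo: thiophen-3-yl in place of iodo gives an at least 1.6-fold higher number from compound 1 to compound 3 (0.21 log units; that floor lies within the scatter), so the exchange brings no lower number in this assay. The true size of the step cannot be read, and compound 1 remains the only compound with a number: the limit of > 20000 nM in this assay, at which 1 of the 3 values shown sits.

The compounds shown leave open whether a smaller halogen such as bromo or chloro, a phenyl ring, or an amine at this carbon would keep or lower the number seen for compound 1. As far as these compounds go, it also remains open how thiophen-3-yl would behave with methylamino in place of methyl.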